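Defined ether configuration within the cyclopentane-ether antagonist series

The source may report more compounds than this note shows. Statements on the series, on what has been measured and on what is new or still open speak of the compounds shown alone.

Compound 2 `O=C(O)CC/C=C\CO[C@@H]1C(OCc2ccc(-c3ccccc3)cc2)CC[C@@H]1N1CCCCC1` is the parent of this note. Within the data shown here, in a functional assay for antagonist activity at thromboxane A2 receptor (Rattus norvegicus) (on this read-out higher numbers stand for weaker binding and lower numbers for tighter binding), compound 2 gives 15.9 nM, the only value shown for it; two further entries carry no single number. Around it stand two related analogues. Compound 1 `O=C(O)CC/C=C\CO[C@H]1[C@@H](OCc2ccc(-c3ccccc3)cc2)CC[C@@H]1N1CCCCC1` gives 31.6 nM; 50.1 nM (2 entries) in this assay, with the several entries of compound 1 in this assay, 31.6 nM; 50.1 nM (2 entries) showing both entries close together. Compound 3 `O=C(O)CC/C=C\CO[C@H]1C(OCc2ccc(-c3ccccc3)cc2)CC[C@@H]1N1CCCCC1` gives 794 nM; 63.1 nM (2 entries), and the several entries of compound 3 in this assay, 794 nM; 63.1 nM (2 entries) shows its two entries widely apart, so its position is uncertain. No pairwise step among these three is worked out; (the fact that one of compounds 1 and 2 is drawn with a defined configuration and the other without, at the place where they differ), the fact that one of compounds 1 and 3 is drawn with a defined configuration and the other without, at the place where they differ and the fact that one of compounds 2 and 3 is drawn with a defined configuration and the other without, at the place where they differ note only that each pair differs in whether one stereocentre is drawn with a configuration.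

Compound 4 `O=C(O)CC/C=C\CO[C@@H]1[C@@H](OCc2ccc(-c3ccccc3)cc2)CC[C@@H]1N1CCCCC1` is the next target. From compound 2 it differs by the two compounds have the same atoms and bonds; at least one stereo element is drawn with a configuration in one of them and without one in the other: 1 of 4 stereo elements differ; a stereocentre at a saturated ring carbon is drawn without a configuration in compound 2 and S in compound 4. Compound 2 is therefore a drawing with one centre open and compound 4 a single defined form of it. Among the measured compounds shown here, with no measured step to lean on, the change from compound 2 to compound 4 is expected to stay within the scatter, or to tighten slightly: the estimate is a 1.1-fold lower number from compound 2 to compound 4 (0.06 log units; within the scatter). Compound 4 is expected to give 14 nM in this assay, within a range of 5 nM to 50 nM.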

Compound 4, dissociation constant: 1000 nM
The estimate for compound 4 lay 71-fold (1.85 log units) below the measured number; the measured number lies above the stated range.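

In this assay the step is a 63-fold higher number from compound 2 to compound 4 (1.80 log units; beyond the scatter), and no atom changes with it: the fact that one of compounds 2 and 4 is drawn with a defined configuration and the other without, at the place where they differ. Fixing this saturated ring carbon as S is therefore no mere detail of drawing, and the value of compound 2 cannot stand for every form that its open drawing covers. The configuration at the place where compound 1 and compound 4 differ also matters, since compound 1 gives 31.6 nM; 50.1 nM (2 entries) and compound 4 gives 1000 nM: the fact that compounds 1 and 4 differ only in the configuration as drawn.

Which form or forms account for the value of compound 2 remains open, and compound 3 does not settle it, given how far apart its entries lie: the several entries of compound 3 in this assay, 794 nM; 63.1 nM (2 entries). Also open, as far as these compounds go, is whether these configurations would carry the same weight with an amide in place of the carboxylic acid.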